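The compounds below may be only part of what the source reports. "The series", "measured", "known", "first", "only" and "open" are said of these compounds alone.

Measured so far:
compound 1 `COc1ccc(OC)c(-c2cc(-c3ccc(Cl)cc3)nn2-c2ccc(S(=O)(=O)NC(C)=O)cc2)c1` in a functional assay on cells (Cancer cell lines, Homo sapiens) for cytotoxicity, read by sulforhodamine B assay, with a stated time of 48 h; a lower number here means a stronger inhibitor of growth, a higher number a weaker inhibitor of growth: 25500 nM
compound 2 `CC(=O)NS(=O)(=O)c1ccc(-n2nc(-c3ccccc3)cc2-c2cc(O)ccc2O)cc1` in this assay: 91300 nM

Compound 2 stands at the higher of the two numbers in this assay, compound 1 at the lower, and the gap between them lies beyond the scatter. The two differ in more than one place, so the pair says nothing about one change alone. Compound 3 `CC(=O)NS(=O)(=O)c1ccc(-n2nc(-c3ccc(Cl)cc3)cc2-c2cc(O)ccc2O)cc1` follows from compound 2 by chloro in place of hydrogen on an aromatic carbon. Among the measured compounds shown here, no single-change step between measured compounds exists to anchor this; in this assay a modest step toward a lower number is expected, possibly within the scatter. The expected value for compound 3 is 50000 nM, within 15000 nM to 150000 nM. That expectation amounts to a step of a 1.8-fold lower number from compound 2 to compound 3 (0.26 log units; within the scatter).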

Compound 3, concentration for 50% growth inhibition: 55300 nM
Beside the measured number, compound 3's estimate is 1.1-fold (0.04 log units) below it; low and high end bracket the measured number.
By their numbers in this assay, from the lowest: compound 1; then compounds 3 and 2 (each within the scatter of the next).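

In this assay, phenyl to 4-chlorophenyl gives a 1.7-fold lower number from compound 2 to compound 3 (0.22 log units; within the scatter), so at this place, para to a large group, chloro shows no change that can be read on the 2,5-dihydroxyphenyl compounds. Among the compounds shown here, with 4-chlorophenyl kept, the other single change gives a 2.2-fold higher number from compound 1 to compound 3 (0.34 log units; beyond the scatter), the first step beyond the scatter, though modest. Nothing measured here gives a cause for either step.

Left open is whether chloro gives a similar step with 2,5-dimethoxyphenyl in place, and whether an amine or a carboxylic acid at this place moves the number beyond the scatter.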